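Piperidine amide series: aryl substituent steps toward tert-butyl

The compounds below may be only part of what the source reports. "The series", "measured", "known", "first", "only" and "open" are said of these compounds alone.

Measured so far:
compound 1 `O=C(c1ccc2c(c1)ncn2-c1ccccc1)N1CCCCC1`, 22 nM
compound 2 `CC(C)c1cccc(-n2cnc3cc(C(=O)N4CCCCC4)ccc32)c1`, 68 nM

Compound 1 is the parent with hydrogen on the aromatic carbon of the pendant phenyl. In an assay on isolated protein for inhibition of 15-hydroxyprostaglandin dehydrogenase [NAD(+)] (Homo sapiens), read by fluorescence, with a stated time of 15 min (on this read-out lower numbers stand for stronger inhibition and higher numbers for weaker inhibition), compound 1 gives 22 nM. Compound 2 carries isopropyl at that position and gives 68 nM in this assay, the higher of the two numbers shown; the step of a 3.1-fold higher number from compound 1 to compound 2 (0.49 log units; beyond the scatter) is modest but beyond the scatter.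

Compound 3 `CC(C)(C)c1cccc(-n2cnc3cc(C(=O)N4CCCCC4)ccc32)c1` is not yet measured. It differs from compound 2 by methyl in place of hydrogen on a saturated chain carbon bound to an aromatic carbon and two saturated chain carbons. Among the compounds with values here, the one measured step that bears on this change is a 3.1-fold higher number from compound 1 to compound 2 (0.49 log units; beyond the scatter), which went from hydrogen to isopropyl on the same aromatic carbon and raised the number. Compound 3 continues in the same direction, so a further rise of similar or smaller size, or none beyond the scatter, is expected; the step of a 1.8-fold higher number from compound 2 to compound 3 (0.25 log units; within the scatter) is the estimate. Compound 3 is expected to give about 120 nM in this assay, within 40 nM to 400 nM.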

Compound 3, half-maximal inhibitory concentration: 171 nM
Compound 3: middle estimate off by 1.4-fold (0.15 log units), on the low side; the measured number falls inside the stated range.
By their numbers in this assay, from the lowest: compound 1; then compound 2; then compound 3.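

Methyl in place of hydrogen on the saturated chain carbon, the change from isopropyl to tert-butyl, gives a 2.5-fold higher number from compound 2 to compound 3 (0.40 log units; beyond the scatter) in this assay and so shows that a single added carbon at this place moves the read-out beyond the scatter. Taken whole, tert-butyl in place of hydrogen on the aromatic carbon gives a 7.8-fold higher number from compound 1 to compound 3 (0.89 log units; beyond the scatter) and is the largest step in the series so far. Hydrogen, isopropyl and tert-butyl now stand in one order of rising numbers with no compound against it, but nothing on hand explains that order.

Still open, on these data alone, is whether an amine, a carboxylic acid or a methoxy group on the same aromatic carbon would reverse the rise and give a number lower than that of compound 1. Also open, as far as these compounds go, is whether a straight butyl chain there would track the branched groups.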